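The source may report more compounds than this note shows. Statements on the series, on what has been measured and on what is new or still open speak of the compounds shown alone.

Measured compounds:
compound 1, `O=C(Nc1cccc(-n2cc(-c3ccncc3)c(-c3ccc(Cl)c(O)c3)n2)c1)Nc1ccc(Cl)c(Cl)c1` — > 32500 nM
compound 2, `COc1cc(-c2nn(-c3cccc(NC(=O)c4ccc(Cl)c(C(F)(F)F)c4)c3)cc2-c2ccncc2)ccc1Cl` — > 32500 nM
compound 3, `O=C(Nc1cccc(-n2cc(-c3ccncc3)c(-c3ccc(Cl)c(O)c3)n2)c1)Nc1cc(C(F)(F)F)cc(C(F)(F)F)c1` — 37100 nM

In a functional assay on MDA-MB-468 cells (Homo sapiens) for inhibition, read by sulforhodamine B assay, with a stated time of 48 h (a lower number here means that less compound is tolerated, a higher number that more compound is tolerated), compound 1 returns only a limit of the assay, > 32500 nM. Compound 2 likewise returns only a limit in this assay, > 32500 nM. Within the data shown here, compound 3 is the one compound of the three that gives a number, 37100 nM, and the evidence at hand comes down to a single observation: the limit of > 32500 nM in this assay, at which 2 of the 3 values shown sit. That number sits close to the limit, so compound 3 is tolerated by the cells to about the same degree as the two compounds whose values are limits; no order among the three can be drawn.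

Compound 4, `O=C(Nc1cccc(-n2cc(-c3ccncc3)c(-c3ccc(Cl)c(O)c3)n2)c1)Nc1cccc(C(F)(F)F)c1`, differs from compound 3 in one place: hydrogen in place of trifluoromethyl on an aromatic carbon. The shared core and the urea are unchanged. Among the measured compounds shown here, no measured pair shows what this particular change does, so the expectation rests on how little spread there is among the three measured compounds, all of which lie at or near the limit.

Compound 4 is therefore expected to show no step beyond the usual scatter, a 1.0-fold higher number from compound 3 to compound 4 (0.01 log units; within the scatter). In this assay compound 4 is estimated at 38000 nM, with a range from 20000 nM to 80000 nM, and a fair chance that only a limit is reported.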

Compound 4, concentration lethal to 50% of the cells: > 32500 nM
Compound 4 was reported as a limit; the forecaster's own chance of this, stated with the estimate: 55%; the middle value lies beyond the limit too.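

Compound 4 returns only a limit, > 32500 nM. No new step can therefore be read, neither from compound 3 nor from compound 1 to compound 4: the limit of > 32500 nM in this assay, at which 3 of the 4 values shown sit.

The compounds shown leave open what hydrogen in place of trifluoromethyl does to the concentration the cells tolerate, and whether compounds 1 to 4 differ at all.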